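The compounds below may be only part of what the source reports. "The series", "measured", "known", "first", "only" and "open" are said of these compounds alone.

The three measured compounds and their values: compound 1 `Cc1n[nH]c2ccc(-c3nc4cnc(N5CCN(C)CC5)cn4c3Nc3ccccc3F)cc12` gives 0% in a functional assay on MV4-11 cells (Homo sapiens) for inhibition, with a stated time of 120 h, tested at 10 uM; on this read-out higher numbers stand for more inhibition at the one concentration tested (going by the name of the read-out) and lower numbers for less inhibition; compound 2 `Cc1n[nH]c2ccc(-c3nc4cnc(N5CCN(C)CC5)cn4c3Nc3ccc(Br)cc3)cc12` gives 83%; compound 3 `COc1ccc(Nc2c(-c3ccc4[nH]nc(C)c4c3)nc3cnc(N4CCN(C)CC4)cn23)cc1` gives 3.32%.

Compound 3 thus sits far below compound 2, the step being a number 79.7 percentage points lower from compound 2 to compound 3 (beyond the scatter), while its distance from compound 1, a number 3.3 percentage points higher from compound 1 to compound 3 (within the scatter), does not separate the two. Compound 4 `Cc1n[nH]c2ccc(-c3nc4cnc(N5CCN(C)CC5)cn4c3Nc3ccccc3)cc12` differs from compound 3 in one place: hydrogen in place of methoxy on an aromatic carbon.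

For the measured compounds named here, no measured step exchanges methoxy for hydrogen, so none bears on the new change directly. What the measured steps do show is that the group on this ring decides the outcome: a number 83 percentage points higher from compound 1 to compound 2 (beyond the scatter) and a number 79.7 percentage points lower from compound 2 to compound 3 (beyond the scatter) are both large, whereas a number 3.3 percentage points higher from compound 1 to compound 3 (within the scatter) stays within the scatter. Only bromo has given a high number; the other two substituents leave the read-out near the floor. Removing the methoxy leaves a plain phenyl, for which the data hold nothing.

The most defensible expectation for compound 4 is therefore a number close to that of compound 3, with a number 6.7 percentage points higher from compound 3 to compound 4 (within the scatter) expected to lie within the scatter. In this assay compound 4 is estimated at 10%, in a range from 0% to 45%, the wide upper end allowing for the unknown behaviour of the unsubstituted ring.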

Compound 4, a percentage reported as inhibition, at one concentration (the size of the read-out at that concentration, not a potency): 0%
Compound 4: the middle estimate sits 10 percentage points above what was measured, within the range that was stated.
By their numbers in this assay, from the lowest: compounds 1, 4 and 3 (each within the scatter of the next); then compound 2.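

Removing the methoxy, the change from 4-methoxyphenyl to phenyl, makes no difference that can be told apart in this assay, with a number 3.3 percentage points lower from compound 3 to compound 4 (within the scatter), so the group para to the large group is not needed to keep the read-out near the floor, and methoxy shows no sign of suppressing a number that the plain ring would otherwise give. The unsubstituted ring now supplies the reference that was missing: no change at the digits printed from compound 1 to compound 4 (within the scatter) places it with the fluoro compound, while a number 83 percentage points lower from compound 2 to compound 4 (beyond the scatter) shows that the high number appears only with bromo present and that hydrogen, fluoro and methoxy do not separate from one another. Nothing in the material given explains why bromo alone stands apart.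

From the compounds shown here alone, what remains open is whether the high number belongs to bromo itself or would also appear with chloro, iodo or trifluoromethyl at the same carbon, and whether a bromo at another carbon of this ring would do the same. The compounds shown also leave untested how an amine or a carboxylic acid in this place would read, and how compound 2 would behave at concentrations other than the single one used.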